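Furan to thiophene on the shared core

The source may report more compounds than this note shows. Statements on the series, on what has been measured and on what is new or still open speak of the compounds shown alone.

Measured compounds:
- compound 1, `COC(=O)c1nc(-c2ccsc2)n(-c2ccc(F)cc2)n1`: 54000 nM
- compound 2, `COC(=O)c1nc(C2CCCCC2)n(-c2ccc(C(F)(F)F)cc2)n1`: > 100000 nM
- compound 3, `COC(=O)c1nc(-c2ccoc2)n(-c2ccc(C(F)(F)F)cc2)n1`: 97200 nM

In a functional assay on Jurkat cells (Homo sapiens) for inhibition, read by MTT assay, with a stated time of 72 h (on this read-out higher numbers stand for weaker inhibition of growth and lower numbers for stronger inhibition of growth), compound 3 gives 97200 nM, the highest of the two numbers recorded; the nearest is compound 1 with 54000 nM, and that gap lies within the scatter. For compound 2 the result of > 100000 nM is only a limit of the assay, not a number.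

Compound 4, `COC(=O)c1nc(-c2ccsc2)n(-c2ccc(C(F)(F)F)cc2)n1`, differs from compound 3 in one place: thiophen-3-yl in place of furan-3-yl on an aromatic carbon. Among the measured compounds shown here, only one measured step exists, an at least 1.0-fold lower number from compound 2 to compound 3 (0.01 log units; that floor lies within the scatter), and it rests on (the limit of > 100000 nM in this assay, at which 1 of the 3 values shown sits), so it tells little about a thiophene for furan exchange. Compound 1, which carries thiophen-3-yl but a different group on the other ring, sits within the scatter of compound 3, so nothing points to a shift beyond the scatter. Compound 4 is therefore expected near 70000 nM, between 30000 nM and 150000 nM. This expected change amounts to a 1.4-fold lower number from compound 3 to compound 4 (0.14 log units; within the scatter).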

Compound 4, concentration for 50% growth inhibition: > 100000 nM
Compound 4: only a limit was reported; the forecaster's own chance of this, stated with the estimate: 30%; middle value at least 1.4-fold (0.15 log units) away from the limit.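

In this assay, compound 4 gives a limit of the assay and not a number, so an at least 1.0-fold higher number from compound 3 to compound 4 (0.01 log units; that floor lies within the scatter) marks only a floor, and thiophen-3-yl in place of furan-3-yl on this aromatic carbon brings no sign of stronger inhibition of growth. With thiophen-3-yl held fixed, trifluoromethyl in place of fluoro on the other ring gives an at least 1.8-fold higher number from compound 1 to compound 4 (0.26 log units; that floor lies within the scatter), so this exchange is also bounded on one side only. The step from the cyclohexyl compound cannot be read, and the series now rests in part on a limit: the limit of > 100000 nM in this assay, at which 2 of the 4 values shown sit.

From the compounds shown here alone, how far compound 4 truly lies from compound 3 stays open. Also open, going by these compounds, is whether an amine or a carboxylic acid on this aromatic carbon would give a number clearly lower than those seen here.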